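Chloro to Methylsulfonyl on the Outer Ring of Compound 1

The source may hold more compounds than are shown below. What is called first, only, known or untested is meant among the compounds shown, and "the series" means these compounds.

Measured so far:
Compound 1 `Cc1oc(C(=O)O)cc1COc1ccc(-c2ccc(Cl)cc2)cc1` gives 1000 nM in an assay on cells for displacement of a labelled ligand from prostaglandin E2 receptor EP4 subtype (Homo sapiens), read by scintillation counting; on this read-out lower numbers stand for stronger inhibition and higher numbers for weaker inhibition.
Compound 2 `Cc1oc(C(=O)O)cc1COc1ccc(-c2ccoc2)cc1` gives only a limit of this assay, > 10000 nM.
Compound 3 `Cc1oc(C(=O)O)cc1COc1ccc(-c2nnco2)cc1` gives only a limit of this assay, > 10000 nM.

Going by the values given here, compound 1 holds the only real number in this set; the two other values are limits, which is also what the limit of > 10000 nM in this assay, at which 2 of the 3 values shown sit, records. Two measured steps start from compound 1. Putting furan-3-yl in place of 4-chlorophenyl gives an at least 10-fold higher number from compound 1 to compound 2 (1.00 log units; beyond the scatter), and putting 1,3,4-oxadiazol-2-yl in place of 4-chlorophenyl gives an at least 10-fold higher number from compound 1 to compound 3 (1.00 log units; beyond the scatter). The step between compound 2 and compound 3 is a step that the two limits leave unreadable from compound 2 to compound 3.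

Compound 4 `Cc1oc(C(=O)O)cc1COc1ccc(-c2ccc(S(C)(=O)=O)cc2)cc1` is a gentler change. It keeps the 4-chlorophenyl's ring and alters only its substituent: methylsulfonyl in place of chloro on an aromatic carbon. Neither measured step touches just this substituent; both swap out the whole 4-chlorophenyl, so they show that losing that group costs binding but say little about exchanging chloro for methylsulfonyl. Without a closer precedent, the expectation is a step of about a 2.0-fold higher number from compound 1 to compound 4 (0.30 log units; within the scatter) in this assay, most likely within the scatter or a slight weakening. Compound 4 is therefore estimated at 2000 nM, with a range from 500 nM to 10000 nM.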

Compound 4, inhibition constant: > 10000 nM
Compound 4 gave a limit, no number; the forecaster's own chance of this, stated with the estimate: 20%; middle value at least 5.0-fold (0.69 log units) away from the limit.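

Here the outer ring stays and only the group on it changes, unlike the earlier steps, which replaced the whole 4-chlorophenyl. In this assay, going by these compounds alone, methylsulfonyl in place of chloro still gives an at least 10-fold higher number from compound 1 to compound 4 (1.00 log units; beyond the scatter), so keeping the outer ring does not by itself preserve the result, and the single group on an aromatic carbon, para to a large group, can decide it. Compound 4 has only a limit of the assay, so this step has a minimum size but no measured size: the limit of > 10000 nM in this assay, at which 3 of the 4 values shown sit.

The compounds shown do not reveal whether chloro is unusual in this place or whether other groups, such as fluoro, methyl or methoxy, would keep a value close to that of compound 1, 1000 nM. They also leave open where a closer relative of methylsulfonyl, such as methylthio, would fall, and whether any group on the outer ring could give a clearly lower number than chloro does.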